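A few compounds are considered here, and "the series" means these few. Any claim that something is new, unique, unknown or untested is made for them only; others in the source may bear on it.

Measured so far:
- compound 1, `CCC(C)C(=O)Nc1c(C(O)(C(F)(F)F)C(F)(F)F)ccc2ccccc12`: 177000 nM
- compound 2, `Cc1cccc(C(=O)Nc2c(C(O)(C(F)(F)F)C(F)(F)F)ccc3ccccc23)c1`: 23 nM

In an assay on LtK cells with ATP-sensitive inward rectifier potassium channel 11 (Homo sapiens) as the target (on this read-out lower numbers stand for an effect already at smaller amounts and higher numbers for an effect only at larger amounts of compound), compound 2 gives 23 nM, the lowest of the two numbers shown. For the measured compounds named here, the only other compound, compound 1, gives 177000 nM, so compound 2 stands far ahead of it, and the single measured step, a 7700-fold lower number from compound 1 to compound 2 (3.89 log units; beyond the scatter), came from exchanging the group on the carbonyl carbon. Compound 3, `O=C(Nc1c(C(O)(C(F)(F)F)C(F)(F)F)ccc2ccccc12)c1cccc(C(F)(F)F)c1`, keeps that aromatic ring and changes only its substituent: trifluoromethyl in place of methyl on an aromatic carbon. Going by the values given here, no measured step touches this position, so the one step on record gives no guide for the size of this change. Without such a precedent, the expected step from compound 2 to compound 3 is a 1.3-fold higher number from compound 2 to compound 3 (0.12 log units; within the scatter), a change that may well stay within the scatter. On that basis compound 3 is estimated at 30 nM in this assay, with a range from 8 nM to 120 nM.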

Compound 3, half-maximal effective concentration: 84 nM
Estimate against measurement, compound 3: 2.8-fold (0.45 log units) below; the range from low to high includes it.
By their numbers in this assay, from the lowest: compound 2; then compound 3; then compound 1.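

The substituent on this aromatic ring does matter in this assay: the result is a 3.7-fold higher number from compound 2 to compound 3 (0.56 log units; beyond the scatter), so the methyl form keeps the lower number of this pair. Even so, this change is small beside a 2100-fold lower number from compound 1 to compound 3 (3.32 log units; beyond the scatter), which shows that the large drop seen on replacing sec-butyl on the carbonyl carbon does not depend on the methyl group, as it also holds with 3-(trifluoromethyl)phenyl. Nothing available bears on what lies behind the difference between the methyl and trifluoromethyl forms.

The compounds shown leave open how an amine or a carboxylic acid would fare in place of methyl on this aromatic carbon. They also leave open whether a longer chain on the carbonyl carbon could come close to these aromatic groups.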